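Methoxy to hydroxy: the step to compound 4

The source may hold more compounds than are shown below. What is called first, only, known or untested is meant among the compounds shown, and "the series" means these compounds.

Compound 1 `COc1cc(-c2nc(-c3ccccc3)[nH]c2-c2ccnc(NCCCNS(=O)(=O)c3ccccc3)n2)ccc1F` gives 4520 nM
Compound 2 `COc1cc(-c2nc(-c3ccccc3)[nH]c2-c2ccnc(NCCCNS(=O)(=O)c3ccccc3)n2)ccc1Cl` gives 7470 nM
Compound 3 `COc1cc(-c2nc(-c3ccccc3)[nH]c2-c2ccnc(NCCCNS(=O)(=O)c3cccc(F)c3)n2)ccc1Cl` gives 5110 nM

In a functional assay on LOX IMVI cells (Homo sapiens) for cytotoxicity, read by MTT assay, with a stated time of 24 h (on this read-out lower numbers stand for stronger inhibition and higher numbers for weaker inhibition), compound 2 (7470 nM) lies within the scatter of both other compounds, so the three values are not separated. Compound 4 `O=S(=O)(NCCCNc1nccc(-c2[nH]c(-c3ccccc3)nc2-c2ccc(Cl)c(O)c2)n1)c1ccccc1` differs from compound 2 by hydrogen in place of methyl on an oxygen on an aromatic ring and carries hydrogen in place of methyl on an oxygen on an aromatic ring, methoxy to hydroxy. The two measured steps bear on this only indirectly. One is a 1.7-fold higher number from compound 1 to compound 2 (0.22 log units; within the scatter) and the other is a 1.5-fold lower number from compound 2 to compound 3 (0.16 log units; within the scatter) and neither alters the methoxy group. Among the compounds with values here, no measured pair shows this change, so no shift beyond the scatter is expected, and the estimated step is a 1.5-fold lower number from compound 2 to compound 4 (0.17 log units; within the scatter) with low confidence in its direction. Compound 4 is estimated at 5000 nM within a range of 1800 nM to 14000 nM on this evidence.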

Compound 4, half-maximal inhibitory concentration: 2630 nM
For compound 4 the middle estimate is 1.9-fold (0.28 log units) above the measured one, and the stated range covers the measured number.
By their numbers in this assay, from the lowest: compounds 4, 1, 3 and 2 (each within the scatter of the next, the first and the last beyond it).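

In this assay the change from methoxy to hydroxy gives a 2.8-fold lower number from compound 2 to compound 4 (0.45 log units; beyond the scatter) on this position, the only step shown here that lies beyond the scatter, whereas the halogen changes in the earlier compounds did not. The change from 4-fluoro-3-methoxyphenyl to 4-chloro-3-hydroxyphenyl gives a 1.7-fold lower number from compound 1 to compound 4 (0.24 log units; within the scatter) and stays within it. Nothing given here accounts for the effect of the hydroxy group.

The compounds shown leave open whether the same step holds with the fluoro of compound 1 or compound 3 present. From the compounds shown here alone, it also remains open how an amine or a longer ether such as ethoxy would read on this oxygen-bearing position.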